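A few compounds are considered here, and "the series" means these few. Any claim that something is new, unique, unknown or untested is made for them only; others in the source may bear on it.

Series notes. The shared core is carried by compound 1 `O=C1C=CC(OCC(F)(F)F)N1c1ccc(C(F)(F)F)cc1`, compound 2 `Cc1ccc(N2C(=O)C=CC2OCC(F)(F)F)cc1` and compound 3 `O=C1C=CC(OCC(F)(F)F)N1c1ccc([N+](=O)[O-])cc1`, which differ only in the group sitting on an aromatic carbon para to a large group. In a functional assay on A549 cells (Homo sapiens) for inhibition (a higher number here means a weaker inhibitor, a lower number a stronger inhibitor), compound 1 gives 8390 nM, compound 2 gives 13700 nM and compound 3 gives 3270 nM. Compound 3 holds the lowest number of the three: the step of a 2.6-fold lower number from compound 1 to compound 3 (0.41 log units; beyond the scatter) and the step of a 4.2-fold lower number from compound 2 to compound 3 (0.62 log units; beyond the scatter) both lie beyond the scatter, whereas a 1.6-fold higher number from compound 1 to compound 2 (0.21 log units; within the scatter) does not, so compound 1 and compound 2 cannot be ordered against each other.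

Compound 4 `COC(=O)c1ccc(N2C(=O)C=CC2OCC(F)(F)F)cc1` has not yet been measured in this assay; it differs from compound 3 by methoxycarbonyl in place of nitro on an aromatic carbon. Among the compounds with values here, the steps that bear on this change are the two that end in nitro, both modest and both giving a lower number as nitro enters. Within the data shown here, nothing has been measured with methoxycarbonyl at this position, so the only guide is that each group replaced by nitro so far gave a modestly higher number. A modest rise in this assay is therefore expected for compound 4, of about a 1.8-fold higher number from compound 3 to compound 4 (0.26 log units; within the scatter). Compound 4 is estimated at 6000 nM in this assay, within a range of 2500 nM to 15000 nM.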

Compound 4, half-maximal inhibitory concentration: 8170 nM
Compound 4: middle estimate off by 1.4-fold (0.13 log units), on the low side; the range from low to high includes it.
By their numbers in this assay, from the lowest: compound 3; then compounds 4, 1 and 2 (each within the scatter of the next).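

Working notes. In this assay, within the data shown here, the lower number of compound 3 now holds against a third group at this position: a 2.5-fold higher number from compound 3 to compound 4 (0.40 log units; beyond the scatter), and with the steps already in hand, nitro is the only group of the four set apart from all the others. Methoxycarbonyl does not separate from the remaining groups, since a 1.7-fold lower number from compound 2 to compound 4 (0.22 log units; within the scatter) and a 1.0-fold lower number from compound 1 to compound 4 (0.01 log units; within the scatter) both stay within the scatter, leaving compound 1, compound 2 and compound 4 unordered among themselves. Nitro and methoxycarbonyl match in their counts of hydrogen-bond donors and acceptors and in double bonds outside aromatic rings, yet their numbers differ, and no measurement at hand accounts for that difference.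

The compounds shown leave open whether the lower number belongs to nitro alone or is shared by other groups on this aromatic carbon, such as a nitrile, a carboxylic acid, an amine or a sulfonamide. They also leave open whether the step from nitro to methoxycarbonyl would hold if the trifluoroethoxy chain on the shared core were replaced by a longer chain.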